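The source may hold more compounds than are shown below. What is called first, only, known or untested is meant among the compounds shown, and "the series" means these compounds.

The series rests on a shared core carrying a thiosemicarbazone arm. Compound 1 `COc1ccc(-c2nc3cc(C(C)O)ccc3[nH]2)cc1` and compound 2 `C/C(=N\NC(N)=S)c1ccc2[nH]c(-c3ccccc3)nc2c1` were both tested in an ADME assay on Vero cells (Chlorocebus sabaeus) for cytotoxicity, read by MTT assay, with a stated time of 96 h; on this read-out lower numbers stand for higher toxicity in this test and higher numbers for lower toxicity in this test. In this assay compound 1 gives > 100000 nM, which is a limit of the assay rather than a number. In this assay compound 2 likewise gives > 100000 nM, again only a limit. Compound 2 therefore stands where every value shown stands, namely at the limit of > 100000 nM in this assay, at which 2 of the 2 values shown sit. Compound 3 `COc1ccc(-c2nc3cc(/C(C)=N/NC(N)=S)ccc3[nH]2)cc1` differs from compound 2 by methoxy in place of hydrogen on an aromatic carbon. For the measured compounds named here, no step between measured compounds is known, so no size of change has been observed in this assay; the two limits offer no direction, and only a change within the scatter, or none at all, is expected. Compound 3 is expected to give 120000 nM in this assay, within 50000 nM to 300000 nM. The estimated step is a step that the limit leaves unreadable from compound 2 to compound 3, most likely again reported as a limit.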

Compound 3, half-maximal cytotoxic concentration: > 100000 nM
Compound 3 gave a limit, no number; the forecaster's own chance of this, stated with the estimate: 85%; the middle value does not contradict the limit.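

In this assay, for the compounds shown here, compound 3 gives > 100000 nM, again a limit, so no step from compound 1 or compound 2 to compound 3 can be read. The compounds shown leave open whether phenyl to 4-methoxyphenyl changes the half-maximal cytotoxic concentration at all.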